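Bromo for Methoxy: Expecting the Growth Inhibition of Compound 4

A few compounds are considered here, and "the series" means these few. Any claim that something is new, unique, unknown or untested is made for them only; others in the source may bear on it.

Of the compounds shown here, three sharing one core have been tested. Compound 1 `COc1ccc(NC(=O)C2(C(=O)Nc3ccc(Nc4ncc5cc(C(=O)N(C)C)n(C6CCCC6)c5n4)cc3)CC2)cc1` gives 96.1% in a functional assay on T47D cells (Homo sapiens) for inhibition, read by CCK-8 assay, with a stated time of 72 h, tested at 10 uM; on this read-out higher numbers stand for more inhibition of growth at the one concentration tested and lower numbers for less inhibition of growth. Compound 2 `CN(C)C(=O)c1cc2cnc(Nc3ccc(NC(=O)C4(C(=O)Nc5ccc(Br)cc5)CC4)cc3)nc2n1C1CCCC1` gives 94.3%, and compound 3 `COc1cccc(NC(=O)C2(C(=O)Nc3ccc(Nc4ncc5cc(C(=O)N(C)C)n(C6CCCC6)c5n4)cc3)CC2)c1` gives 93.5%; the step of a number 0.8 percentage points lower from compound 2 to compound 3 (within the scatter) is small. Compound 4 `CN(C)C(=O)c1cc2cnc(Nc3ccc(NC(=O)C4(C(=O)Nc5cccc(Br)c5)CC4)cc3)nc2n1C1CCCC1` is not yet measured.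

From compound 1 to compound 2 the change is bromo in place of methoxy on an aromatic carbon, and it gave the step of a number 1.8 percentage points lower from compound 1 to compound 2 (within the scatter). The cores of compound 1 and compound 3 differ by 3-methoxyphenyl in place of 4-methoxyphenyl on an amide-type nitrogen, with the step of a number 2.6 percentage points lower from compound 1 to compound 3 (within the scatter). From compound 3 to compound 4 the change is bromo in place of methoxy on an aromatic carbon; since the place is meta to a large group rather than para to a large group, this is the same kind of change, not the same one.

The step from compound 3 to compound 4 is expected to be a number 1.5 percentage points lower from compound 3 to compound 4 (within the scatter), resting on the earlier step of a number 1.8 percentage points lower from compound 1 to compound 2 (within the scatter) of compound 1 to compound 2. Compound 4 is therefore estimated at 92%, within 84% to 98%.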

Compound 4, percent growth inhibition at one concentration: 94.6%
Estimate against measurement, compound 4: 2.6 percentage points below; low and high end bracket the measured number.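

In this assay, bromo in place of methoxy has now been seen on two cores, and the two results agree as far as this read-out can tell: the same change on two cores in this assay, a number 1.8 percentage points lower (within the scatter) from compound 1 to compound 2 and a number 1.1 percentage points higher (within the scatter) from compound 3 to compound 4, 2.9 percentage points apart, within the scatter of two such steps. The swap itself gave a number 1.1 percentage points higher from compound 3 to compound 4 (within the scatter), 3-bromophenyl in place of 4-bromophenyl gave a number 0.3 percentage points higher from compound 2 to compound 4 (within the scatter), and 3-bromophenyl in place of 4-methoxyphenyl gave a number 1.5 percentage points lower from compound 1 to compound 4 (within the scatter). So the swap carried from one core to the other without a step beyond the scatter, but this does not show that bromo and methoxy are equivalent, as a read-out at one concentration cannot tell how much of each compound is needed.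

The compounds shown leave open what an amine or a carboxylic acid in place of the bromo would give in this assay.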